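The source may hold more compounds than are shown below. What is called first, only, known or untested is meant among the compounds shown, and "the series" means these compounds.

Working notes on the ester series. Compound 1 `Cc1nc(C)c(C(=O)Oc2ccccc2/C=C/C(=O)O)nc1C`, compound 2 `COc1ccc(/C=C/C(=O)O)c(OC(=O)c2nc(C)c(C)nc2C)c1` and compound 3 `COc1cc(/C=C/C(=O)O)ccc1OC(=O)c1nc(C)c(C)nc1C` have been measured in a functional assay on EA.hy 926 cells (Homo sapiens) for cytotoxicity, read by MTT assay, with stated times of 24 h and 12 h, tested at 25 uM; a higher number here means a stronger effect of the compound at the concentration tested, a lower number a weaker effect; compound 4 `COc1cc(/C=C/C(=O)O)cc(OC)c1OC(=O)c1nc(C)c(C)nc1C` has not. In this assay compound 1 gives 61.8%, compound 2 gives -52.1% and compound 3 gives 40.3%. Within the data shown here, the one counted step so far, (methoxy in place of hydrogen on an aromatic carbon), runs a number 113.9 percentage points lower from compound 1 to compound 2 (beyond the scatter). The difference between the core of compound 1 and the core of compound 3 is not broken down here. The change from compound 3 to compound 4, (methoxy in place of hydrogen on an aromatic carbon), is the same kind of change, but its surroundings differ: in compound 2 the entering methoxy sits meta to a large group and para to a 2-carboxyethenyl group, whereas in compound 4 it sits ortho to a large group, meta to a 2-carboxyethenyl group and meta to a methoxy group. Because a number 113.9 percentage points lower from compound 1 to compound 2 (beyond the scatter) was large and downward, a downward step is expected here too, though a smaller one given the different surroundings, estimated as a number 40.3 percentage points lower from compound 3 to compound 4 (beyond the scatter). Compound 4 is therefore estimated at 0% in this assay, expected to lie between -60% and 45%.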

Compound 4, a percentage reported as activity, at one concentration (the size of the read-out at that concentration, not a potency): 24%
Estimate against measurement, compound 4: 24 percentage points below; the measured number falls inside the stated range.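

In this assay, methoxy in place of hydrogen on an aromatic carbon again lowers the number, here as a number 16.3 percentage points lower from compound 3 to compound 4 (beyond the scatter), so the direction holds on both cores but the size does not carry over: the same change on two cores in this assay, a number 113.9 percentage points lower (beyond the scatter) from compound 1 to compound 2 and a number 16.3 percentage points lower (beyond the scatter) from compound 3 to compound 4, 97.6 percentage points apart, beyond the scatter of two such steps
The downward direction rests on these two pairs alone and cannot be claimed as a rule for the series. The pairs also do not show what sets the size of the step, since the entering methoxy has different surroundings in each; in compound 4 it sits ortho to a large group, meta to a 2-carboxyethenyl group and meta to a methoxy group, and two pairs cannot separate these features from the change of core.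

Still open, on these data alone, is whether a hydroxy or an ethoxy group in the place of the entering methoxy would lower the number in the same way. Also open, as far as these compounds go, is whether the step would persist if an amide replaced the carboxylic acid of the 2-carboxyethenyl group.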